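A few compounds are considered here, and "the series" means these few. Any claim that something is new, unique, unknown or untested is made for them only; others in the source may bear on it.

Compound 3 `CCCCSC1=N[C@H](C(=O)OC)[C@@H]2C(=O)N(c3ccccc3)C(=O)[C@H]12` gives 89% in a functional assay for inhibition, tested at 100 uM (on this read-out higher numbers stand for more inhibition at the one concentration tested (going by the name of the read-out) and lower numbers for less inhibition), level with compound 2 `CCSC1=N[C@H](C(=O)OC)[C@@H]2C(=O)N(c3ccccc3)C(=O)[C@H]12`, which gives 89% in this assay, and together they are the highest of the three numbers. Compound 1 `COC(=O)[C@H]1N=C(SC(C)C)[C@H]2C(=O)N(c3ccccc3)C(=O)[C@H]21` gives 72% in this assay. From it, a number 17 percentage points higher from compound 1 to compound 3 (beyond the scatter). Compound 4 `COC(=O)[C@H]1N=C(SC)[C@H]2C(=O)N(c3ccccc3)C(=O)[C@H]21` differs from compound 3 in one place: hydrogen in place of propyl on a saturated chain carbon bound to a sulfur. Because no change at the digits printed from compound 2 to compound 3 (within the scatter) likewise changed only the length of the unbranched chain on the sulfur, that step bears most on this one; the rises a number 17 percentage points higher from compound 1 to compound 2 (beyond the scatter) and a number 17 percentage points higher from compound 1 to compound 3 (beyond the scatter) both start from isopropyl and say nothing about chain length. No step beyond the scatter is therefore expected, so that a number 4 percentage points lower from compound 3 to compound 4 (within the scatter). Compound 4 is estimated to give 85% in this assay, between 70% and 95%.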

Compound 4, a percentage reported as inhibition, at one concentration (the size of the read-out at that concentration, not a potency): 84%
Estimate against measurement, compound 4: 1 percentage points above; the range from low to high includes it.
By their numbers in this assay, from the lowest: compound 1; then compounds 4, 2 and 3 (each within the scatter of the next).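

Methyl on the sulfur extends the unbranched series in this assay (a number 5 percentage points lower from compound 3 to compound 4 (within the scatter); a number 5 percentage points lower from compound 2 to compound 4 (within the scatter)), so methyl, ethyl and butyl cannot be told apart here. Isopropyl remains the one group set apart, now also from methyl (a number 12 percentage points higher from compound 1 to compound 4 (beyond the scatter)), and all three unbranched chains stand beyond the scatter from it. No evidence available here bears on the reason for this.

The compounds shown leave open whether a longer chain such as octyl, or a phenyl or cyclohexyl ring on the sulfur, would hold this level. They also leave open how another branched group, such as tert-butyl, would compare with isopropyl.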